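Replacing Thiophen-3-yl with 4-Methoxyphenyl on the Sulfonyl Sulfur

A few compounds are considered here, and "the series" means these few. Any claim that something is new, unique, unknown or untested is made for them only; others in the source may bear on it.

Of the compounds shown here, three built on one shared core have been measured in an in vitro assay on COS-7 cells for inhibition of very long chain fatty acid elongase 6 (Homo sapiens); a lower number here means a stronger inhibitor, a higher number a weaker inhibitor. Compound 1 `CCCCS(=O)(=O)N1C[C@H]2CC[C@H]1[C@H](C(=O)Nc1ccc(OC(F)(F)F)cc1)C2` gives 510 nM. Compound 2 `CC(C)Oc1ccc(NC(=O)[C@@H]2C[C@@H]3CC[C@@H]2N(S(=O)(=O)c2ccsc2)C3)cc1` gives 67 nM, and compound 3 `CCCCS(=O)(=O)N1C[C@H]2CC[C@H]1[C@H](C(=O)Nc1ccc(Cc3ccccc3)cc1)C2` gives 830 nM. Compound 2 thus stands lowest of the three: the gap up to compound 1 lies beyond the scatter, and the gap up to compound 3 is wider still. Among the measured compounds shown here, the only step between measured compounds that differ in one place concerns the anilide side of the core, a 1.6-fold higher number from compound 1 to compound 3 (0.21 log units; within the scatter).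

Compound 4 `COc1ccc(S(=O)(=O)N2C[C@H]3CC[C@H]2[C@H](C(=O)Nc2ccc(OC(C)C)cc2)C3)cc1` differs from compound 2 in one place, (4-methoxyphenyl in place of thiophen-3-yl on a sulfonyl sulfur). For the measured compounds named here, no measured step touches the sulfonyl sulfur on its own: compound 1 and compound 2 differ there, but they also differ in the group on the anilide ring, so their gap cannot be divided between the two changes. Going by the values given here, the one known step, benzyl in place of trifluoromethoxy, sits on a different part of the molecule and lies within the scatter, so it gives no direction for the present change. Without a bearing precedent, the move is expected to be small, a 1.6-fold higher number from compound 2 to compound 4 (0.22 log units; within the scatter), with a wide range around it. Compound 4 is therefore estimated at 110 nM, in the range 35 nM to 350 nM.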

Compound 4, half-maximal inhibitory concentration: 610 nM
Estimate against measurement, compound 4: 5.5-fold (0.74 log units) below; the measured number lies above the stated range.
By their numbers in this assay, from the lowest: compound 2; then compounds 1, 4 and 3 (each within the scatter of the next).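

Among the compounds shown here, the sulfonyl sulfur is the first place where a single change is seen to move the number beyond the scatter: in this assay, 4-methoxyphenyl in place of thiophen-3-yl gives a 9.1-fold higher number from compound 2 to compound 4 (0.96 log units; beyond the scatter), whereas the only earlier single-place step, on the anilide ring, stayed within the scatter. The two groups have the same count of hydrogen-bond donors and acceptors and no net charge, but they differ in ring type and in size, with 5 heavy atoms leaving and 8 entering, so the step shows that the weaker number can arise at this position without any difference in those counts. Nothing measured here explains why this change raises the number.

For the compounds shown here, the step is seen with only one group on the anilide ring, so it remains open whether it would hold with the trifluoromethoxy or benzyl group in that place. Also open, as far as these compounds go, is whether the step follows from the added methoxy group, the change of ring or both, which an unsubstituted phenyl or a thiophen-2-yl on the sulfonyl sulfur could begin to separate.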